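Methoxy for methyl in the histamine agonist series

A few compounds are considered here, and "the series" means these few. Any claim that something is new, unique, unknown or untested is made for them only; others in the source may bear on it.

Compound 2 `Cc1ccc(C(CC/N=C(\N)NCCCc2c[nH]cn2)c2ccccn2)cc1` gives 1 in a functional assay on muscle tissue for agonist activity at histamine H2 receptor (Cavia porcellus) (a lower number here means a smaller maximal response, a higher number a larger maximal response), and stands highest of the two numbers in hand. Compound 1 `N=C(NCCCc1c[nH]cn1)NCCC(c1ccccc1)c1ccccn1` gives 0.7 in this assay, a gap from compound 2 beyond the scatter. Compound 3 `COc1ccc(C(CC/N=C(\N)NCCCc2c[nH]cn2)c2ccccn2)cc1` differs from compound 2 by methoxy in place of methyl on an aromatic carbon. For the measured compounds named here, no measured pair covers this change, so nothing measured shows its size. The change is expected to bring a number 0.050 lower from compound 2 to compound 3 (within the scatter) in this assay, a step of no size beyond the scatter. For compound 3 the estimated maximal response in this assay is 0.95, between 0.75 and 1.05.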

Compound 3, intrinsic activity: the largest response reached, as a fraction of the reference agonist's: 0.5
For compound 3 the middle estimate is 0.45 above the measured one; the measured number lies below the stated range.
By their numbers in this assay, from the lowest: compound 3; then compound 1; then compound 2.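

In this assay, going from 4-methylphenyl to 4-methoxyphenyl is far from a neutral exchange: the change brings a number 0.50 lower from compound 2 to compound 3 (beyond the scatter). The maximal response therefore depends strongly on which group sits at this position, para to a large group, even though the exchange adds only one oxygen and one hydrogen-bond acceptor. No measured property accounts for the drop. Still open, from the compounds shown here alone, is whether the loss follows the oxygen itself or the larger group, which an ethyl group or a hydroxyl group at this position would help separate. Chlorine or an amine there would show how far the response tolerates other substituents.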